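This account rests on a few compounds, and the source may have more. Where it says the series, first, only, none or still open, it means among the compounds named here.

Compound 1 `CCCn1c(=O)[nH]c2nc(-c3ccc(S(=O)(=O)N4CCN(Cc5cccc(C)c5)CC4)cc3)[nH]c2c1=O` was tested in an assay on CHO cells for displacement of a labelled ligand from adenosine receptor A1 (Homo sapiens), read by scintillation counting, with a stated time of 90 min, in the presence of a further agent that is not named here (a higher number here means a weaker inhibitor, a lower number a stronger inhibitor), and gave 795 nM. Of the two numerical values in this assay it is the higher one; its nearest neighbour, compound 2 `CCCn1c(=O)[nH]c2nc(-c3ccc(S(=O)(=O)N(C)C)cc3)[nH]c2c1=O`, gave in this assay 190 nM, a lower number by a margin that lies beyond the usual scatter. Compound 3 `CCCn1c(=O)[nH]c2nc(-c3ccc(S(=O)(=O)N4CCN(c5cccc(Cl)c5)CC4)cc3)[nH]c2c1=O` is reported in this assay only as a limit, > 1000 nM, not as a number. Going by the values given here, the one measured step that starts from compound 1, an at least 1.2-fold higher number from compound 1 to compound 3 (0.09 log units; that floor lies within the scatter), put 3-chlorophenyl in place of 3-methylbenzyl on an amine nitrogen in a ring; its size cannot be fixed because of the limit of > 1000 nM in this assay, at which 1 of the 3 values shown sits.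

Compound 4 `CCCn1c(=O)[nH]c2nc(-c3ccc(S(=O)(=O)N4CCN(Cc5cccc(Br)c5)CC4)cc3)[nH]c2c1=O` differs from compound 1 by bromo in place of methyl on an aromatic carbon of a six-membered aromatic ring of carbon only, while the benzyl arm itself is kept. The step of an at least 1.2-fold higher number from compound 1 to compound 3 (0.09 log units; that floor lies within the scatter) altered far more than this single atom and still gave no number, so it offers no measured guide to a swap of this size. Compound 4 is therefore expected to show a step of a 1.1-fold higher number from compound 1 to compound 4 (0.05 log units; within the scatter), not beyond the scatter. For compound 4 the estimate is 900 nM, with a range from 400 nM to 2000 nM.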

Compound 4, inhibition constant: 928 nM
For compound 4 the middle estimate is 1.0-fold (0.01 log units) below the measured one; low and high end bracket the measured number.
By their numbers in this assay, from the lowest: compound 2; then compounds 1 and 4 (each within the scatter of the next). At a limit, above all of these: compound 3.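

Bromo in place of methyl on an aromatic carbon is the first change in this series with a number at both ends, and in this assay it gives a 1.2-fold higher number from compound 1 to compound 4 (0.07 log units; within the scatter). At this place, with the benzyl arm kept, the swap of methyl for bromo therefore gives no measurable separation between the two compounds, which the earlier step to the 3-chlorophenyl compound could not show. The value of compound 3 is a limit. The step of an at least 1.0-fold lower number from compound 3 to compound 4 (0.03 log units; that floor lies within the scatter), 3-bromobenzyl in place of 3-chlorophenyl on an amine nitrogen in a ring, therefore cannot be read and says nothing about the 3-bromobenzyl arm against the 3-chlorophenyl group: the limit of > 1000 nM in this assay, at which 1 of the 4 values shown sits.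

From the compounds shown here alone, it remains open whether another group on this aromatic carbon, such as methoxy, an amine or a carboxylic acid, would shift the number beyond the scatter, or whether only small groups like methyl and bromo behave alike here. Also open, going by these compounds, is what an unsubstituted benzyl arm, or a longer chain between the amine nitrogen in the ring and the aromatic ring, would give.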